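This account rests on a few compounds, and the source may have more. Where it says the series, first, only, none or still open, it means among the compounds named here.

In a functional assay for inhibition of nuclear factor NF-kappa-B complex (Homo sapiens) (a lower number here means a stronger inhibitor, a higher number a weaker inhibitor), three compounds have been measured so far:

Compound 1, `CCOC(=O)C1=Cc2ccc(OC)cc2OC1c1cc(OC)c(OC)c(OC)c1`, gives 25000 nM.
Compound 2, `CCCCNC(=O)C1=Cc2ccc(OC)cc2OC1c1cc(OC)c(OC)c(OC)c1`, gives 25500 nM.
Compound 3, `COc1ccc2c(c1)OC(c1cc(OC)c(OC)c(OC)c1)C(C#N)=C2`, gives 3400 nM.

Compound 3 stands with the lowest number of the three. Compounds 1 and 2 differ only by butylamino in place of ethoxy on a carbonyl carbon, and the step of a 1.0-fold higher number from compound 1 to compound 2 (0.01 log units; within the scatter) lies within the scatter. Against either of them, the change to cyano on a double-bonded ring carbon brings a clear drop: a 7.4-fold lower number from compound 1 to compound 3 (0.87 log units; beyond the scatter) and a 7.5-fold lower number from compound 2 to compound 3 (0.88 log units; beyond the scatter).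

Compound 4, `COc1ccc2c(c1)OC(c1cc(OC)c(OC)c(OC)c1)C(C(=O)N(C)C)=C2`, has not yet been measured. It differs from compound 3 in one place: dimethylcarbamoyl in place of cyano on a double-bonded ring carbon. Within the data shown here, the step from compound 3 to compound 4 therefore runs the earlier steps in reverse, putting a carbonyl-bearing group back where the cyano of compound 3 sits. The entering dimethylcarbamoyl is, like the butylcarbamoyl of compound 2, an amide, and the steps of a 7.5-fold lower number from compound 2 to compound 3 (0.88 log units; beyond the scatter) and a 7.4-fold lower number from compound 1 to compound 3 (0.87 log units; beyond the scatter) were of modest but similar size. On that basis the number for compound 4 is expected to rise beyond the scatter, by roughly the size of those steps, giving an estimated 4.4-fold higher number from compound 3 to compound 4 (0.64 log units; beyond the scatter). The estimate for compound 4 is 15000 nM, with a range from 5000 nM to 40000 nM.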

Compound 4, half-maximal inhibitory concentration: > 50000 nM
Compound 4 ended at the assay's limit; the forecaster's own chance of this, stated with the estimate: 10%; at least 3.3-fold (0.52 log units) between middle value and limit.
By their numbers in this assay, from the lowest: compound 3; then compounds 1 and 2 (each within the scatter of the next). At a limit, above all of these: compound 4.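

In this assay, among these compounds, compound 4 gives > 50000 nM, which is a limit of the assay and not a number, and the only such value here: the limit of > 50000 nM in this assay, at which 1 of the 4 values shown sits. On the double-bonded ring carbon, the change from nitrile to dimethylcarbamoyl gives an at least 14-fold higher number from compound 3 to compound 4 (1.16 log units; beyond the scatter), so a short amide with no butyl chain does not keep the lower number of compound 3, and the nitrile remains the only group shown at this position with a number clearly below the others. The comparison with the other carbonyl-bearing compounds is less firm, as an at least 1.9-fold higher number from compound 2 to compound 4 (0.29 log units; that floor lies within the scatter) and an at least 2.0-fold higher number from compound 1 to compound 4 (0.30 log units; that floor lies within the scatter) have floors that only reach the edge of the scatter, so no order among compounds 1, 2 and 4 can be claimed.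

The compounds shown leave open whether the low number belongs to the nitrile alone or could also be reached with a different group at this position, such as a carboxylic acid, a primary amide or an aminomethyl group. They also give no measured reason for the step, and the true value of compound 4 stays unknown.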